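From benzyl to 3-fluorobenzyl on the shared core

A few compounds are considered here, and "the series" means these few. Any claim that something is new, unique, unknown or untested is made for them only; others in the source may bear on it.

Values from a functional assay on MT4 cells (Homo sapiens) for cytotoxicity, read by MTT assay (a higher number here means that more compound is tolerated, a lower number that less compound is tolerated), follow
Compound 1 `Cc1c(O)nc(SCc2ccccc2)nc1Cc1c(Cl)cccc1Cl` gives > 64000 nM (a limit)
Compound 2 `COc1cc(CSc2nc(O)c(C)c(Cc3c(F)cccc3F)n2)cc(OC)c1` gives > 60000 nM (a limit)
Compound 3 `Cc1c(O)nc(SCc2ccc(C(C)C)cc2)nc1Cc1c(F)cccc1F` gives > 62000 nM (a limit)

Compound 1 therefore stands at a limit and not at a number, and the same holds for compound 2 and compound 3. Compound 4 `Cc1c(O)nc(SCc2cccc(F)c2)nc1Cc1c(Cl)cccc1Cl` keeps the core of compound 1 and has fluoro in place of hydrogen on an aromatic carbon, turning benzyl into 3-fluorobenzyl fluoro in place of hydrogen on an aromatic carbon in this one place. Among the measured compounds shown here, no two measured compounds differ in one place only, so the data offer no measured step as a guide. In this assay no change beyond the usual scatter is expected, in either direction. The expectation starts from compound 1 at > 64000 nM as a limit. The estimated step of an at least 1.0-fold lower number from compound 1 to compound 4 (0.02 log units; that floor lies within the scatter) is expected to be small. The assay may well report only a limit again. For compound 4 the expected value is 61000 nM, with an estimated range of 30000 nM to 90000 nM.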

Compound 4, half-maximal cytotoxic concentration: > 61000 nM
Compound 4: no number, only a limit (the forecaster's own chance of this, stated with the estimate: 80%); the middle value sits exactly at the limit.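

In this assay, compound 1 and compound 4 both stand at limits and not at numbers, so the step between them cannot be read. The compounds shown leave open whether fluoro in place of hydrogen changes the tolerated concentration at all; none of them gives a number.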